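A few compounds are considered here, and "the series" means these few. Any claim that something is new, unique, unknown or untested is made for them only; others in the source may bear on it.

Measured compounds in an ADME assay for pharmacokinetics, at pH 7.4; on this read-out lower numbers stand for a shorter-lived compound and higher numbers for a longer-lived compound:
- compound 1 `COc1cnc(C[S+]([O-])c2nc3cc(OC(F)F)ccc3[nH]2)cc1OC`: > 200 h
- compound 2 `COc1cnc(C[S+]([O-])c2nc3cc(OC(F)F)ccc3[nH]2)c(C)c1OC`: 60 h
- compound 3 `COc1ccnc(C[S+]([O-])c2nc3cc(OC(F)(F)C(F)F)ccc3[nH]2)c1`: 63 h

The value of compound 1 is a limit of the assay, not a number. For that reason the step of an at least 3.3-fold lower number from compound 1 to compound 2 (0.52 log units; beyond the scatter) is itself a lower bound, because of the limit of > 200 h in this assay, at which 1 of the 3 values shown sits. The change behind it is methyl in place of hydrogen on an aromatic carbon.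

Compound 3 differs from compound 1 in the core; that difference is not broken down here. Against compound 2, compound 3 sits within the scatter, so no order is read between them.

Compound 4 `COc1cc(C[S+]([O-])c2nc3cc(OC(F)(F)C(F)F)ccc3[nH]2)ncc1C` carries the same kind of change relative to compound 3: methyl in place of hydrogen on an aromatic carbon. The surroundings are not identical: in compound 2 the entering methyl is ortho to a large group and meta to a methoxy group, whereas in compound 4 it is para to a large group, so the two steps are of the same kind rather than the same.

Resting on the step from compound 1 to compound 2, a shortening of similar size is expected from compound 3 to compound 4, a 3.2-fold lower number from compound 3 to compound 4 (0.50 log units; beyond the scatter). Compound 4 is estimated at 20 h in this assay, with a range from 8 h to 50 h.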

Compound 4, half-life in the ADME assay: 18 h
Estimate against measurement, compound 4: 1.1-fold (0.05 log units) above; low and high end bracket the measured number.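

In the ADME assay methyl in place of hydrogen on an aromatic carbon gives a 3.5-fold lower number from compound 3 to compound 4 (0.54 log units; beyond the scatter). In the ADME assay this repeats on a second core the direction of an at least 3.3-fold lower number from compound 1 to compound 2 (0.52 log units; beyond the scatter). Two cores give a shared direction but no rule for the whole series, and how closely the size carries over stays unsettled: the same change on two cores in the ADME assay, an at least 3.3-fold lower number (0.52 log units; beyond the scatter) from compound 1 to compound 2 and a 3.5-fold lower number (0.54 log units; beyond the scatter) from compound 3 to compound 4; the limit leaves it open whether they differ. In the ADME assay compound 1 gives > 200 h as a limit of the assay and not as a number.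

In a physicochemical assay for acid dissociation, compound 3 gives 4.25 and compound 4 gives 4.95. In the physicochemical assay the same change gives a number 0.70 log units higher from compound 3 to compound 4 (beyond the scatter). As far as these compounds go, whether a shift of this kind goes along with the half-life step on the core of compound 1 stays open. Also open, from the compounds shown here alone, is whether an ethyl group or a chlorine atom in place of the entering methyl would shorten the half-life in the same way on either core.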